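The source may report more compounds than this note shows. Statements on the series, on what has been measured and on what is new or still open speak of the compounds shown alone.

Working notes on the series. Compound 1 `c1ccc(Oc2ccc3c(NCCCNCc4ccco4)ccnc3c2)cc1` gives 317 10^-6 cm/s in an ADME assay for permeability, using PAMPA, with a stated time of 30 min, at pH 7.4; on this read-out higher numbers stand for higher permeability and lower numbers for lower permeability. Going by the values given here, compound 2 `c1ccc(-c2ccc3c(NCCCNCc4ccco4)ccnc3c2)cc1` gives 237 10^-6 cm/s in this assay; the one step between measured neighbours, a 1.3-fold lower number from compound 1 to compound 2 (0.13 log units; within the scatter), phenyl in place of phenoxy on an aromatic carbon, stays within the scatter. Compound 3 `COc1cccc(CNCCCNc2ccnc3cc(Oc4ccc(Cl)cc4)ccc23)c1O` gives 317 10^-6 cm/s in this assay, level with compound 1 at the digits printed; against compound 2 the two values differ only within the scatter, so no order among the three is claimed.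

Compound 4 `COc1cccc(CNCCCNc2ccnc3cc(CCC(C)C)ccc23)c1O` is the next step, (isopentyl in place of 4-chlorophenoxy on an aromatic carbon). Among the compounds with values here, the only measured step, a 1.3-fold lower number from compound 1 to compound 2 (0.13 log units; within the scatter), exchanges one group for another at an aromatic carbon of the shared core without moving the number beyond the scatter. That step exchanges an aryl ether for an aryl group, not for an isopentyl chain, so it bears on the present change only loosely and nothing measured separates an alkyl chain from an aryl ether here. Compound 4 is therefore expected to sit close to compound 3, with the step of a 1.1-fold lower number from compound 3 to compound 4 (0.02 log units; within the scatter) estimated to lie within the scatter. For compound 4 in this assay the estimate is 300 10^-6 cm/s, with a range from 150 10^-6 cm/s to 550 10^-6 cm/s.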

Compound 4, apparent permeability: 23 10^-6 cm/s
Estimate against measurement, compound 4: 13-fold (1.12 log units) above, and the stated range ends above it.
By their numbers in this assay, from the lowest: compound 4; then compounds 2, 1 and 3 (each within the scatter of the next).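

The step of a 14-fold lower number from compound 3 to compound 4 (1.14 log units; beyond the scatter) in this assay, isopentyl in place of 4-chlorophenoxy on an aromatic carbon, lies beyond the scatter, so on this read-out the group at this position can matter. The earlier step, a 1.3-fold lower number from compound 1 to compound 2 (0.13 log units; within the scatter), stayed within the scatter and kept a six-membered aromatic ring of carbon only at this position, whereas the isopentyl group brings no ring and no hydrogen-bond acceptor in place of the one ring and one acceptor that leave. Nothing measured here bears on the reason for the large step.

The change from compound 3 to compound 4 alters the ring, the ether oxygen and the number of heavy atoms at once, so the compounds shown leave open which of these goes with the lower number, and they leave the link between the two side chains and this position untested. A cyclohexyl group or a benzyl group at this position on the core of compound 3 would separate these features, while a longer chain would show whether the isopentyl result holds across alkyl groups.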